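Notes on thiophen-2-yl in place of methylsulfanyl

The compounds below may be only part of what the source reports. "The series", "measured", "known", "first", "only" and "open" are said of these compounds alone.

Of the compounds shown here, two carry numbers so far. In a physicochemical assay for solubility, in phosphate buffer, with a stated time of 18 h (a lower number here means a less soluble compound, a higher number a more soluble compound), compound 1 (`N#Cc1c(N)nc2nc(C3CCC3)ncc2c1N`) gives 217000 nM and compound 2 (`CSc1nc(C(C)(C)C)nc2nc(N)c(C#N)c(N)c12`) gives 14000 nM in the same measurement. Compound 2 therefore stands lowest of the two, and its gap to compound 1 lies beyond the scatter. Within the data shown here, these two compounds differ in more than one place, so their gap offers no measured step for the change considered here.

The next compound is compound 3 (`CC(C)(C)c1nc(-c2cccs2)c2c(N)c(C#N)c(N)nc2n1`), where thiophen-2-yl stands in place of methylsulfanyl on an aromatic carbon next to the ring nitrogen (thiophen-2-yl in place of methylsulfanyl on an aromatic carbon). Among the measured compounds shown here, with no step available for this change, the expectation rests only on compound 2 at 14000 nM as the starting point and on the structural change itself. A moderate fall in this assay is expected, modestly beyond the scatter, with a result inside the scatter still possible. The expected change is a 2.8-fold lower number from compound 2 to compound 3 (0.45 log units; beyond the scatter) as a working estimate. For compound 3 the estimated value is 5000 nM with an expected range of 1500 nM to 16000 nM in this buffer.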

Compound 3, solubility: 56000 nM
Beside the measured number, compound 3's estimate is 11-fold (1.05 log units) below it, and the stated range ends below it.
By their numbers in this assay, from the lowest: compound 2; then compound 3; then compound 1.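

In this assay, among these compounds, this is the first measured step for the position on an aromatic carbon next to the ring nitrogen, since the gap between compound 1 and compound 2 spans more than one place and gives no reading for it. Thiophen-2-yl in place of methylsulfanyl there gives a 4.0-fold higher number from compound 2 to compound 3 (0.60 log units; beyond the scatter) and so the exchange of the small open group for the five-membered aromatic ring comes with a modest rise in the read-out, not a fall, on a core that keeps the tert-butyl group. Nothing in hand shows what lies behind the direction or the size of this step.

A single step on a single background leaves open whether the rise belongs to thiophen-2-yl itself or would also appear with another ring at this position, such as phenyl or pyridyl, or with an amine or a longer chain in the same place. On these data alone, it also remains open whether the step would hold on a core without the tert-butyl group, as compound 1 differs from compound 3 in more than one place and cannot answer that.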